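A 1H-indol-5-yl group in place of compound 2's group

The compounds below may be only part of what the source reports. "The series", "measured", "known", "first", "only" and "open" are said of these compounds alone.

In a functional assay on K562 cells (Homo sapiens) for inhibition, read by trypan blue exclusion, with a stated time of 72 h (a higher number here means a weaker inhibitor, a lower number a stronger inhibitor), compound 1 (`Cn1c(=O)c(C(=O)Nc2ccc(F)cc2F)cc2cnc(Nc3ccc4[nH]ccc4c3)nc21`) gives 5000 nM and compound 2 (`Cc1ccc(S(=O)(=O)c2cc3cnc(Nc4cnc5[nH]ccc5c4)nc3n(C)c2=O)cc1`) gives 15000 nM as the higher of the two numbers. This gap lies beyond the usual scatter and makes compound 2 the weaker inhibitor of the pair. Compound 3 (`Cc1ccc(S(=O)(=O)c2cc3cnc(Nc4ccc5[nH]ccc5c4)nc3n(C)c2=O)cc1`) has not yet been measured. The change from compound 2 to compound 3 is a group of 9 heavy atoms (8 carbon, 1 nitrogen; one five-membered aromatic ring with 1 hetero atom, one six-membered aromatic ring of carbon only) in place of a group of 9 heavy atoms (7 carbon, 2 nitrogen; one five-membered aromatic ring with 1 hetero atom, one six-membered aromatic ring with 1 hetero atom), on a nitrogen on an aromatic ring and nothing else differs. Going by the values given here, no measured pair shows this change alone, so its size cannot be read directly from the data. The 1H-indol-5-yl group also occurs in compound 1, which gives 5000 nM with a different remainder of the structure. Among the compounds with values here, that single value is the only guide, and it points towards a lower number, meaning a stronger inhibitor, with considerable uncertainty. The expected step is a 3.0-fold lower number from compound 2 to compound 3 (0.48 log units; beyond the scatter) and would lie modestly beyond the scatter. For compound 3 the estimated value is 5000 nM with an expected range from 1500 nM to 15000 nM across repeated measurements.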

Compound 3, half-maximal inhibitory concentration: 750 nM
Compound 3: middle estimate off by 6.7-fold (0.82 log units), on the high side; the whole stated range lies above it.
By their numbers in this assay, from the lowest: compound 3; then compound 1; then compound 2.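

In this assay, the group on the nitrogen on an aromatic ring proves decisive: with (4-methylphenyl)sulfonyl held in place, 1H-indol-5-yl, whose six-membered aromatic ring is of carbon only, gives a 20-fold lower number from compound 2 to compound 3 (1.30 log units; beyond the scatter), a large step from a change of a single ring atom in a group of equal heavy-atom count. The second place now also has a reading, since with 1H-indol-5-yl held in place, (4-methylphenyl)sulfonyl in place of (2,4-difluorophenyl)carbamoyl on an aromatic carbon gives a 6.7-fold lower number from compound 1 to compound 3 (0.82 log units; beyond the scatter), a modest step in the same direction, so that compound 3 stands lowest of the three. No measurement here accounts for either step.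

The compounds shown leave open whether 1H-indol-5-yl would give a step of similar size with (2,4-difluorophenyl)carbamoyl on the aromatic carbon, since only one of the two matching compounds is present. They also leave open how a piperazine or a carboxylic acid would behave in place of (4-methylphenyl)sulfonyl at that aromatic carbon, with 1H-indol-5-yl kept on the nitrogen.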